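The source may hold more compounds than are shown below. What is called first, only, known or untested is meant among the compounds shown, and "the series" means these compounds.

Compound 1, `COc1ccc(C(=O)NCCNc2nc3cc(C)cc(C)c3cc2C#N)cc1`, and compound 2, `COc1ccc(C(=O)NCCNc2nc3cc(C)cc(C)c3cc2C#N)cc1OC`, share one core and differ at a single place. In an in vitro assay on FRT cells with Cystic fibrosis transmembrane conductance regulator variant F508del (Homo sapiens) as the target, read by fluorescence, with a stated time of 24 h, at 37 degrees C, in the presence of a further agent that is not named here (a higher number here means that more compound is needed for the effect, a lower number that less compound is needed), compound 1 gives 3000 nM. In this assay compound 2 gives 1500 nM. Among the measured compounds shown here, the only measured step, a 2.0-fold lower number from compound 1 to compound 2 (0.30 log units; within the scatter), comes from methoxy in place of hydrogen on an aromatic carbon, so compound 2 stands beside compound 1 within the usual scatter, and no ordering between the two can be read from these numbers.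

Compound 3, `COc1ccc(C(=O)NCCNc2nc3cc(C)cc(C)c3cc2C#N)nc1`, has not yet been measured. It differs from compound 2 by 5-methoxypyridin-2-yl in place of 3,4-dimethoxyphenyl on a carbonyl carbon. For the measured compounds named here, only one measured step bears on this change, and only in part: it shows that adding or removing one methoxy on this aromatic ring, a 2.0-fold lower number from compound 1 to compound 2 (0.30 log units; within the scatter), stays within the scatter. Nothing measured speaks to a ring nitrogen in this position. The expectation is therefore a step of a 2.0-fold higher number from compound 2 to compound 3 (0.30 log units; within the scatter), not beyond the scatter. Compound 3 is estimated at 3000 nM in this assay, with a range from 1000 nM to 10000 nM.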

Compound 3, half-maximal effective concentration: 2700 nM
The estimate for compound 3 lay 1.1-fold (0.05 log units) above the measured number; the range from low to high includes it.
By their numbers in this assay, from the lowest: compounds 2, 3 and 1 (each within the scatter of the next).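

In this assay, the earlier step changed only the number of methoxy groups on the ring, whereas this result replaces the ring itself. Exchanging 3,4-dimethoxyphenyl for 5-methoxypyridin-2-yl on the carbonyl carbon gives a 1.8-fold higher number from compound 2 to compound 3 (0.26 log units; within the scatter), and exchanging 4-methoxyphenyl for the same group gives a 1.1-fold lower number from compound 1 to compound 3 (0.05 log units; within the scatter), so a ring with one hetero atom can stand here without moving the number beyond the scatter in either comparison. No measurement shown here accounts for these numbers.

With all three compounds within the scatter of one another, the compounds shown do not reveal any change at this position that moves the number beyond the scatter, so this position's influence on the number remains undefined. As far as these compounds go, it also remains open how the number would respond to an amine or a carboxylic acid in place of the methoxy group on the 5-methoxypyridin-2-yl ring, or to a longer chain joining the amide nitrogen to the shared core.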